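Swapping the para substituent on compound 3: ethoxy to methyl

This account rests on a few compounds, and the source may have more. Where it says the series, first, only, none or still open, it means among the compounds named here.

Three compounds have been measured in a functional assay on FM3A cells (Mus musculus) for inhibition, read by cell counting, with a stated time of 2 days; on this read-out lower numbers stand for stronger inhibition and higher numbers for weaker inhibition:
- compound 1 `C=C(Br)C(=O)Nc1cccc(-c2cn3nc(-c4ccc(CC)cc4)sc3n2)c1` gives 3300 nM
- compound 2 `C=C(Br)C(=O)Nc1cccc(-c2cn3nc(Cc4ccccc4)sc3n2)c1` gives 3000 nM
- compound 3 `C=C(Br)C(=O)Nc1cccc(-c2cn3nc(-c4ccc(OCC)cc4)sc3n2)c1` gives 1100 nM

Compound 3 stands lowest of the three in this assay, separated from both others by steps beyond the scatter: a 3.0-fold lower number from compound 1 to compound 3 (0.48 log units; beyond the scatter) and a 2.7-fold lower number from compound 2 to compound 3 (0.44 log units; beyond the scatter). Compound 4 `C=C(Br)C(=O)Nc1cccc(-c2cn3nc(-c4ccc(C)cc4)sc3n2)c1` differs from compound 3 by methyl in place of ethoxy on an aromatic carbon. The step that bears most on this is the one from ethyl to ethoxy, a 3.0-fold lower number from compound 1 to compound 3 (0.48 log units; beyond the scatter); the step of a 1.1-fold lower number from compound 1 to compound 2 (0.04 log units; within the scatter) shows that ethyl and benzyl give similar numbers. Since methyl, like ethyl, carries no acceptor, a modest move back toward the numbers of compounds 1 and 2 is expected in this assay, that is a 2.3-fold higher number from compound 3 to compound 4 (0.36 log units; beyond the scatter). Compound 4 is therefore estimated at 2500 nM, with a range from 1000 nM to 6000 nM.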

Compound 4, half-maximal inhibitory concentration: 1200 nM
Compound 4: middle estimate off by 2.1-fold (0.32 log units), on the high side, and the stated range covers the measured number.
By their numbers in this assay, from the lowest: compounds 3 and 4 (each within the scatter of the next); then compounds 2 and 1 (each within the scatter of the next).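

Methyl, which carries no hydrogen-bond acceptor, in place of ethoxy gives a 1.1-fold higher number from compound 3 to compound 4 (0.04 log units; within the scatter) in this assay, so an acceptor on this ring carbon is not required for a number at this level. Ethyl sits apart from both: methyl in place of ethyl gives a 2.8-fold lower number from compound 1 to compound 4 (0.44 log units; beyond the scatter), so the numbers do not simply follow group size, and 4-methylphenyl in place of benzyl gives a 2.5-fold lower number from compound 2 to compound 4 (0.40 log units; beyond the scatter). Nothing measured here offers a reason for this. Still open, going by these compounds, is how a longer chain such as butoxy, an amine or a carboxylic acid would fare at this position.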